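The compounds below may be only part of what the source reports. "The series", "measured", "known", "first", "only" and "open" are said of these compounds alone.

Measured compounds:
compound 1, `CN(C)CCCNc1nc(-c2ccc(NC(=O)Nc3ccccc3F)cc2)nc2ccsc12`, in a functional assay on NCI-H460 cells (Homo sapiens) for cytotoxicity, read by MTT assay, with a stated time of 72 h (on this read-out lower numbers stand for stronger inhibition and higher numbers for weaker inhibition), compound 1 gives 530 nM
compound 2, `CCN(CC)CCCNc1nc(-c2ccc(NC(=O)Nc3ccccc3Cl)cc2)nc2ccsc12`, compound 2 gives 200 nM
compound 3, `CCN(CC)CCNc1nc(-c2ccc(NC(=O)Nc3ccccc3F)cc2)nc2ccsc12`, compound 3 gives 430 nM

Compound 3 stands second highest of the three numbers in this assay, closest to compound 1 and furthest from compound 2. Going by the values given here, the one single-place step known, a 1.2-fold lower number from compound 1 to compound 3 (0.09 log units; within the scatter), lies within the scatter. Compound 4, `CCN(CC)CCNc1nc(-c2ccc(NC(=O)Nc3ccccc3Cl)cc2)nc2ccsc12`, differs from compound 3 by chloro in place of fluoro on an aromatic carbon. Among the compounds with values here, no measured step isolates this change. Compound 2 and compound 3 differ in two places, the halogen and the amine chain; their values show a gap beyond the scatter, compound 2 giving the lower number, while the step from compound 1 to compound 3 shows that a change of the chain alone stayed within the scatter. On that indirect reading, the chloro group is expected to bring a lower number, a 1.7-fold lower number from compound 3 to compound 4 (0.24 log units; within the scatter), and compound 4 is estimated at 250 nM, with a range from 120 nM to 550 nM.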

Compound 4, half-maximal inhibitory concentration: 320 nM
Compound 4: middle estimate off by 1.3-fold (0.11 log units), on the low side; the measured number falls inside the stated range.
By their numbers in this assay, from the lowest: compounds 2, 4, 3 and 1 (each within the scatter of the next, the first and the last beyond it).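

In this assay, chloro in place of fluoro on an aromatic carbon, ortho to a large group, can now be read directly, and it gives a 1.3-fold lower number from compound 3 to compound 4 (0.13 log units; within the scatter), so this read-out does not separate the two halogens on the diethylamino chain. With chloro held fixed, diethylamino in place of (diethylamino)methyl gives a 1.6-fold higher number from compound 2 to compound 4 (0.20 log units; within the scatter), so this chain change also stays within the scatter. Nothing measured here accounts for either step.

The compounds shown leave open whether a bromo or a methyl group at this place, or a longer chain ending in diethylamino, would move the number beyond the scatter. They also leave open whether chloro and fluoro would stay this close on a chain ending in a pyrrolidine.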